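Compound 3 to compound 4: a step among limits

The source may hold more compounds than are shown below. What is called first, only, known or untested is meant among the compounds shown, and "the series" means these compounds.

In an ADME assay on HepG2 cells (Homo sapiens) for cytotoxicity, read by MTT assay, with a stated time of 72 h (on this read-out higher numbers stand for lower toxicity in this test and lower numbers for higher toxicity in this test), all three measured compounds end at a limit and none gives a number. Compound 1 (`COc1ccc(-c2cc(Cl)cn3c([N+](=O)[O-])c(CS(=O)(=O)c4ccccc4)nc23)cc1`) gives > 3900 nM, which is a limit. Compound 2 (`O=Cc1ccc(-c2cc(Cl)cn3c([N+](=O)[O-])c(CS(=O)(=O)c4ccccc4)nc23)cc1`) gives > 31200 nM, which is also a limit. Compound 3 (`O=[N+]([O-])c1c(CS(=O)(=O)c2ccccc2)nc2c(-c3cccc(F)c3)cc(Cl)cn12`) gives > 12500 nM, again a limit, so it has no readable position relative to the other two.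

Compound 4 (`O=[N+]([O-])c1c(CS(=O)(=O)c2ccccc2)nc2c(-c3ccccc3C(F)(F)F)cc(Cl)cn12`) carries 2-(trifluoromethyl)phenyl in place of 3-fluorophenyl on an aromatic carbon ortho to a fused ring: 2-(trifluoromethyl)phenyl in place of 3-fluorophenyl on an aromatic carbon.

Two measured steps exchange the group at this place: a step that the two limits leave unreadable from compound 1 to compound 3 and a step that the two limits leave unreadable from compound 2 to compound 3. The remaining step changes a substituent on that group: a step that the two limits leave unreadable from compound 1 to compound 2. None of the three gives a size to carry over, so no step beyond the scatter is expected in this assay, in either direction. The expected step is a step that the limit leaves unreadable from compound 3 to compound 4. Compound 4 is estimated at 14000 nM, with an expected range of 5000 nM to 40000 nM.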

Compound 4, half-maximal cytotoxic concentration: 22700 nM
Compound 4: middle estimate off by 1.6-fold (0.21 log units), on the low side, within the range that was stated.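

In this assay, going by these compounds alone, compound 4 gives 22700 nM, the first readable number at this position, here with 2-(trifluoromethyl)phenyl on the aromatic carbon. Within the data shown here, the one readable step is an at least 1.3-fold lower number from compound 2 to compound 4 (0.13 log units; that floor lies within the scatter) and so the exchange of 4-formylphenyl for 2-(trifluoromethyl)phenyl gives a lower number, though this floor alone shows no change beyond the usual scatter. The steps to compound 4 from compound 1 and from compound 3 cannot be read, as each of those two compounds ends at a limit.

Going by these compounds, how far compound 1, compound 2 and compound 3 truly lie from compound 4 stays open, since none of them has a number. In this assay, on these data alone, it is also open how an amine or a carboxylic acid on the phenyl ring at this position would read.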